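The compounds below may be only part of what the source reports. "The series", "measured", "known", "first", "only" and "open" are said of these compounds alone.

Of the compounds shown here, three have been measured in an assay on CHO-TREX cells for antagonist activity at transient receptor potential cation channel subfamily A member 1 (Homo sapiens), read by FLIPR and calcium flux, with a stated time of 10 min; on this read-out higher numbers stand for weaker inhibition and lower numbers for stronger inhibition. Compound 1 `Fc1ccc(C(F)(F)F)c(-c2ccc3[nH]ncc3c2)c1` gives 306 nM in this assay. Compound 2 `Cn1ncc2cc(-c3ccccc3C(F)(F)F)ccc21` gives 7410 nM in this assay. Compound 3 `CCc1cc2[nH]ncc2cc1-c1ccccc1C(F)(F)F` gives 50 nM in this assay, the lowest number of the three; its gap to compound 1 and its gap to compound 2 both lie beyond the usual scatter of repeated measurements, so compound 3 is the strongest inhibitor among them.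

Compound 4 `N#Cc1cc2[nH]ncc2cc1-c1ccccc1C(F)(F)F` has not yet been measured. It differs from compound 3 in one place: cyano in place of ethyl on an aromatic carbon. Among the measured compounds shown here, no pair of measured compounds shows this change, so there is nothing within the set to size it by. Only a modest effect is expected, leaning toward weaker inhibition. For compound 4 the expected step is a 3.0-fold higher number from compound 3 to compound 4 (0.48 log units; beyond the scatter). Compound 4 is therefore estimated to give about 150 nM in this assay, with a range from 40 nM to 600 nM.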

Compound 4, half-maximal inhibitory concentration: 129 nM
Beside the measured number, compound 4's estimate is 1.2-fold (0.07 log units) above it, within the range that was stated.
By their numbers in this assay, from the lowest: compound 3; then compound 4; then compound 1; then compound 2.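

In this assay cyano in place of ethyl on this aromatic carbon gives a 2.6-fold higher number from compound 3 to compound 4 (0.41 log units; beyond the scatter) as the first measured size for any change at this position. The step is modest, so this carbon carries either of two groups of the same heavy-atom count, ethyl with no hydrogen-bond acceptor and cyano with one, and compound 4 still gives 129 nM in this series. No measured evidence bearing on the reason for this step is available.

As far as these compounds go, whether a methyl, a chlorine atom, a longer chain such as propyl or an amine on this carbon would give a lower or a higher number than ethyl remains open. Also open, from the compounds shown here alone, is whether the same change would give a step of similar size on the core of compound 1 or compound 2.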